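Losing a methyl from the strongest of three inhibitors

The source may report more compounds than this note shows. Statements on the series, on what has been measured and on what is new or still open speak of the compounds shown alone.

Of the compounds shown here, three have been tested in a functional assay on OVCAR-3 cells (Homo sapiens) (a higher number here means a weaker inhibitor of growth, a lower number a stronger inhibitor of growth), so far. Compound 1 (`Oc1cc(-c2ccc(Cl)cc2)nc2ncccc12`) stands at 23400 nM and compound 3 (`COc1ccccc1-c1cc(O)c2c(C)ccnc2n1`) at 12900 nM while compound 2 (`COc1cccc(-c2cc(O)c3cc(C)cnc3n2)c1`) gives 41.7 nM as the lowest number of the three. Both other compounds lie far above compound 2, beyond the scatter, which makes it the strongest inhibitor of growth in this small set.

Compound 4 (`COc1cccc(-c2cc(O)c3cccnc3n2)c1`) has not yet been measured. It is compound 2 with hydrogen in place of methyl on an aromatic carbon, two atoms from the ring nitrogen.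

Among the compounds with values here, no measured pair isolates this change, so its size cannot be read directly from the data. Compound 3 carries a methyl on the core and still gives 12900 nM as its number, yet it differs from compound 2 in more than that one place. Compound 1 has no such methyl, but it differs in other places too. A weakening beyond the scatter is expected, smaller than the gaps that separate compound 2 from the other two. The estimated change is a 7.2-fold higher number from compound 2 to compound 4 (0.86 log units; beyond the scatter) in this assay as the expected outcome. Compound 4 is expected at 300 nM (estimated range 60 nM to 2500 nM).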

Compound 4, concentration for 50% growth inhibition: 55 nM
Beside the measured number, compound 4's estimate is 5.5-fold (0.74 log units) above it; measured number outside the range, below it.
By their numbers in this assay, from the lowest: compounds 2 and 4 (each within the scatter of the next); then compounds 3 and 1 (each within the scatter of the next).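

In this assay, within the data shown here, the exchange of methyl for hydrogen on this aromatic carbon gives a 1.3-fold higher number from compound 2 to compound 4 (0.12 log units; within the scatter), the first direct reading of this change, and the two compounds cannot be told apart. The low number of compound 2 therefore does not depend on the methyl two atoms from the ring nitrogen: with hydrogen in that place, the growth inhibition stays in the same range. Nothing available here bears on why this position accepts the exchange so readily.

Going by these compounds, only methyl and hydrogen have been compared at this carbon, so it remains open whether a longer chain such as ethyl, an amine or a carboxylic acid there would leave the number in this range or move it beyond the scatter. Also open, on these data alone, is whether the exchange would read the same way on a molecule that differs elsewhere, since compound 1 and compound 3 each differ from these two in more than one place and so cannot answer that question.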